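The source may report more compounds than this note shows. Statements on the series, on what has been measured and on what is new or still open speak of the compounds shown alone.

Measured so far in an in vitro ADME assay on microsomes from liver (Canis lupus familiaris) for metabolic stability; a lower number here means slower removal, a higher number faster removal of the compound:
- compound 1 `CC[C@H](C)[C@@H]1C(=O)N[C@H](C2Cc3ccccc3C2)C(=O)N1[C@@H](C(=O)N(C)C)c1cnc(C)cc1C`: 1 mL.min-1.g-1
- compound 2 `CC[C@H](C)[C@@H]1C(=O)N[C@H](C2Cc3ccccc3C2)C(=O)N1[C@@H](C(=O)NC)c1cnc(C)cc1C`: 4 mL.min-1.g-1

For the measured compounds named here, compound 1 holds the lower of the two numbers in this assay, and compound 2 is its only neighbour. Going by the values given here, the one measured step is a 4.0-fold higher number from compound 1 to compound 2 (0.60 log units; beyond the scatter), a modest change beyond the scatter, with hydrogen in place of methyl on an amide-type nitrogen.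

Compound 3 `CC[C@H](C)[C@@H]1C(=O)N[C@H](C2Cc3ccccc3C2)C(=O)N1[C@@H](C(=O)N(C)C)c1cc(C)cnc1C` keeps the amide of compound 1 and the shared core, and differs as follows: 2,5-dimethylpyridin-3-yl in place of 4,6-dimethylpyridin-3-yl on a saturated chain carbon bound to an amide-type nitrogen in a ring and a carbonyl carbon. This puts 2,5-dimethylpyridin-3-yl in place of 4,6-dimethylpyridin-3-yl on a saturated chain carbon bound to an amide-type nitrogen in a ring and a carbonyl carbon.

Among the compounds with values here, no measured step touches this place, so the step to compound 2 serves only as a rough gauge of size for one change. With compound 1 at 1 mL.min-1.g-1, the lower of the two numbers, any shift is expected to be small and upward, though a step beyond the scatter cannot be excluded. The expected step is a 2.0-fold higher number from compound 1 to compound 3 (0.30 log units; within the scatter). For compound 3 the estimated value in this assay is 2 mL.min-1.g-1, with an expected range of 1 mL.min-1.g-1 to 6 mL.min-1.g-1.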

Compound 3, intrinsic clearance in microsomes: 2 mL.min-1.g-1
Beside the measured number, compound 3's estimate shows no gap at the digits printed, and the stated range covers the measured number.
By their numbers in this assay, from the lowest: compounds 1, 3 and 2 (each within the scatter of the next, the first and the last beyond it).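

In this assay, the first change measured at this place, 2,5-dimethylpyridin-3-yl in place of 4,6-dimethylpyridin-3-yl on a saturated chain carbon bound to an amide-type nitrogen in a ring and a carbonyl carbon, gives a 2.0-fold higher number from compound 1 to compound 3 (0.30 log units; within the scatter), so this one pair shows no separation between the two dimethylpyridinyl groups. For the compounds shown here, the two groups have the same atoms joined differently, which makes this a test of the arrangement alone, and that rearrangement gives a step within the scatter, unlike the amide change, which gives a 4.0-fold higher number from compound 1 to compound 2 (0.60 log units; beyond the scatter) and remains the only single-place step beyond the scatter. Nothing available bears on why the two dimethylpyridinyl groups read alike.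

It remains open whether the amide step carries over when 2,5-dimethylpyridin-3-yl replaces 4,6-dimethylpyridin-3-yl, since the pair needed for that comparison is not among the compounds shown. Also open, on these data alone, is how this place responds to a larger change of group, such as an unsubstituted phenyl ring, a pyridine ring without methyl groups or a ring bearing a carboxylic acid, as one pair of isomeric groups says nothing about those.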